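The source may hold more compounds than are shown below. What is called first, only, known or untested is meant among the compounds shown, and "the series" means these compounds.

Three close relatives of one core have been tested in a functional assay on MIA PaCa-2 cells (Homo sapiens) for inhibition, read by MTT assay, with a stated time of 7 days; a higher number here means a weaker inhibitor, a lower number a stronger inhibitor. Compound 1 `CCOC(=O)C1CCN(S(=O)(=O)c2ccc(S(=O)(=O)N(CC)CC)cc2)CC1` carries an ethyl ester, and in this assay compound 1 gives 27200 nM. Compound 3 `CCOC(=O)[C@@H]1CCCN(S(=O)(=O)c2cccc(S(=O)(=O)N(CC)CC)c2)C1` is also an ethyl ester. In this assay compound 3 reaches only a limit, > 30000 nM. Compound 2 `CCN1CC(NC(=O)[C@@H]2CCCN(S(=O)(=O)c3ccc(S(=O)(=O)N(CC)CC)cc3)C2)C1` replaces the ester with an amide to a 1-ethylazetidin-3-yl group. For compound 2, this assay again reports only a limit, > 30000 nM. Compound 2 therefore stands at the weak end of everything shown, at the limit of > 30000 nM in this assay, at which 2 of the 3 values shown sit.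

Compound 4 `CCN(CC)S(=O)(=O)c1ccc(S(=O)(=O)N2CCC[C@@H](C(=O)NC3CN(S(C)(=O)=O)C3)C2)cc1` differs from compound 2 in one place: methylsulfonyl in place of ethyl on an amine nitrogen in a ring. Among the compounds with values here, no measured pair shows what this exchange does. The starting point is a limit, and no compound shown is strong, so the expected step is a step that the limit leaves unreadable from compound 2 to compound 4, nothing beyond the usual scatter. Compound 4 is estimated at 35000 nM, with a range from 15000 nM to 100000 nM, and most likely only a limit will be reported.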

Compound 4, half-maximal inhibitory concentration: 2500 nM
Compound 4: the middle estimate sits 14-fold (1.15 log units) above what was measured; the whole stated range lies above it.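

In this assay, methylsulfonyl in place of ethyl on the amine nitrogen of the four-membered ring gives an at least 12-fold lower number from compound 2 to compound 4 (1.07 log units; beyond the scatter). Within the data shown here, this is the first step that can be read between two compounds differing in one place, and it shows that this ring nitrogen is a position where a single exchange moves the number well beyond the scatter. The true size of the step remains unknown, and it could be larger than printed, because compound 2 reached only a limit: the limit of > 30000 nM in this assay, at which 2 of the 4 values shown sit.

The compounds shown do not say whether the sulfonyl group itself matters, since an acetyl group or an unsubstituted amine on the same nitrogen would be needed to tell. On these data alone, a longer chain on the sulfonyl, such as ethylsulfonyl, also remains open.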